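A few compounds are considered here, and "the series" means these few. Any claim that something is new, unique, unknown or untested is made for them only; others in the source may bear on it.

In a functional assay on the whole organism (Tail, strain ICR) with Mus musculus as the target, in the tail flick test, with a stated time of 60 min, at a dose of 25 umol/kg by the oral route (a higher number here means a stronger effect of the compound at the dose given, a lower number a weaker effect), the three measured compounds give these readings:

- compound 1 `O=C(CN(c1nc(Cl)nc2[nH]cnc12)C1CC1)N[C@@H](CO)C(=O)OCc1ccccc1` gives 34.2%
- compound 2 `O=C(CN(c1nc(Cl)nc2[nH]cnc12)C1CC1)N[C@@H](CC(=O)OCc1ccccc1)C(=O)OCc1ccccc1` gives 22.4%
- compound 3 `O=C(CN(c1nc(Cl)nc2[nH]cnc12)C1CC1)N[C@@H](CCC(=O)OCc1ccccc1)C(=O)OCc1ccccc1` gives 53.7%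

Compound 3 stands highest of the three, with compound 1 nearest and compound 2 furthest. The three differ only in the side chain on the carbon that carries the amide nitrogen and the ester carbonyl, and that chain matters: the step of a number 11.8 percentage points lower from compound 1 to compound 2 (beyond the scatter) lowered the activity, whereas a number 19.5 percentage points higher from compound 1 to compound 3 (beyond the scatter) and a number 31.3 percentage points higher from compound 2 to compound 3 (beyond the scatter) raised it, the last one by a large amount.

Compound 4 `CC[C@H](C)[C@H](NC(=O)CN(c1nc(Cl)nc2[nH]cnc12)C1CC1)C(=O)OCc1ccccc1` changes that same position once more: sec-butyl in place of 2-(benzyloxycarbonyl)ethyl on a saturated chain carbon bound to an amide-type nitrogen and a carbonyl carbon. For the measured compounds named here, no measured step removes the ester from the chain altogether, so the three steps seen offer only a rough guide. They show that lengthening the chain helped and that shortening it hurt, and compound 4 carries a short chain without the ester. A step of a number 20.7 percentage points lower from compound 3 to compound 4 (beyond the scatter) is therefore expected, downward, back toward the range of compounds 1 and 2. For compound 4 the estimate is 33%, with a range from 15% to 52%.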

Compound 4, a percentage reported as activity, at one dose (the size of the read-out at that dose, not a potency): 40.6%
The estimate for compound 4 lay 7.6 percentage points below the measured number, within the range that was stated.
By their numbers in this assay, from the lowest: compound 2; then compounds 1 and 4 (each within the scatter of the next); then compound 3.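

In this assay, the side chain at this position does not need a benzyl ester or an aromatic ring to give a clear reading, since sec-butyl has neither. Sec-butyl ranks between the two ester chains: a number 18.2 percentage points higher from compound 2 to compound 4 (beyond the scatter) shows a gain over (benzyloxycarbonyl)methyl, while a number 13.1 percentage points lower from compound 3 to compound 4 (beyond the scatter) shows a loss against 2-(benzyloxycarbonyl)ethyl, and a number 6.4 percentage points higher from compound 1 to compound 4 (within the scatter) means that sec-butyl and hydroxymethyl cannot be told apart. Nothing available explains why the side chains fall in this order.

From the compounds shown here alone, it remains open how a carboxylic acid at the end of the chain, an amine, or an unbranched hexyl chain would read at this carbon. A single dose and time point also cannot show whether this order would hold at other doses or times.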